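Removing the amino group from a weak stilbene

A few compounds are considered here, and "the series" means these few. Any claim that something is new, unique, unknown or untested is made for them only; others in the source may bear on it.

Measured compounds:
- compound 1, `COc1ccc(/C=C\c2ccc3c(c2)C(C)(C)CCC3(C)C)cc1`: > 100000 nM
- compound 2, `COc1ccc(/C=C/c2ccc3c(c2)C(C)(C)CCC3(C)C)cc1N`: 85000 nM

In a functional assay on HL-60 cells (Homo sapiens), with a stated time of 48 h (on this read-out lower numbers stand for an effect already at smaller amounts and higher numbers for an effect only at larger amounts of compound), compound 1 reaches only the limit of the assay, > 100000 nM, and gives no number. For the measured compounds named here, compound 2 gives 85000 nM in this assay, the single actual number among the two values, and it sits well toward the weak end of the read-out. Compound 1 and compound 2 differ in more than one place, so their two values say only that one is a limit and the other a weak number; nothing is computed between them. The evidence thus amounts to the limit of > 100000 nM in this assay, at which 1 of the 2 values shown sits, with compound 2 standing just inside the measurable range.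

Compound 3, `COc1ccc(/C=C/c2ccc3c(c2)C(C)(C)CCC3(C)C)cc1`, has not yet been tested. It differs from compound 2 by hydrogen in place of amino on an aromatic carbon. Going by the values given here, no step between measured compounds covers this change, so no size or direction can be read off for it. Compound 3 is therefore expected to stay near compound 2, with a step of a 1.4-fold lower number from compound 2 to compound 3 (0.15 log units; within the scatter) within the usual scatter, and its estimated value in this assay is 60000 nM, between 8000 nM and 300000 nM.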

Compound 3, concentration for half-maximal activity: > 100000 nM
Compound 3: no number, only a limit; the forecaster's own chance of this, stated with the estimate: 35%; middle value at least 1.6-fold (0.22 log units) away from the limit.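

Replacing the amino group with hydrogen on this aromatic carbon, ortho to a methoxy group, gives an at least 1.1-fold higher number from compound 2 to compound 3 (0.07 log units; that floor lies within the scatter). For the compounds shown here, this leaves compound 2 as the only compound of the three with an actual number in this assay, but the floor of the step does not clear the usual scatter, so the data do not show that the amino group makes a real difference at this position; the true size of the step could be small or much larger. The comparison of the double-bond configuration also yields nothing, as the step from compound 1 to compound 3 cannot be read, since both compounds stop at the same limit: the limit of > 100000 nM in this assay, at which 2 of the 3 values shown sit.

On these data alone, it remains open whether another group at this position, such as a hydroxyl, a dimethylamino group or an acetamide, would give a value well inside the measurable range of this assay. As far as these compounds go, it is equally open how far compound 1 and compound 3 lie beyond the limit, and so whether the Z and E double bonds differ at all in this read-out.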